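Cytotoxicity: sec-butyl to cyclopentyl on sulfur

The source may report more compounds than this note shows. Statements on the series, on what has been measured and on what is new or still open speak of the compounds shown alone.

- compound 1 `CC(C)Sc1nc(O)cc(C(C)c2ccccc2)n1`: > 200000 nM
- compound 2 `CCC(C)Sc1nc(O)cc(C(C)c2ccccc2)n1`: 200000 nM

All values come from a functional assay on MT4 cells (Homo sapiens) for cytotoxicity; a lower number here means that less compound is tolerated, a higher number that more compound is tolerated. Compound 1 at > 200000 nM is a limit, not a number. Among the measured compounds shown here, compound 2 at 200000 nM holds the only actual number so far. For the measured compounds named here, the sole measured step is a number no higher from compound 1 to compound 2 (the limit leaves the size open), and its size stays open.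

Compound 3 `CC(c1ccccc1)c1cc(O)nc(SC2CCCC2)n1` brings (cyclopentyl in place of sec-butyl on a sulfur). Going by the values given here, no measured step covers cyclopentyl in place of sec-butyl on a sulfur, so no change beyond the scatter is expected in this assay. The expected step is a 1.2-fold lower number from compound 2 to compound 3 (0.07 log units; within the scatter). For compound 3 the estimate is 170000 nM, with an expected range of 60000 nM to 400000 nM.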

Compound 3, half-maximal cytotoxic concentration: 159000 nM
Beside the measured number, compound 3's estimate is 1.1-fold (0.03 log units) above it; the measured number falls inside the stated range.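

In this assay, among the compounds shown here, cyclopentyl is the first ring on this sulfur, and it yields a 1.3-fold lower number from compound 2 to compound 3 (0.10 log units; within the scatter), so a ring in place of the open sec-butyl chain makes no difference beyond the scatter here. With cyclopentyl in place of isopropyl on a sulfur, the result is an at least 1.2-fold lower number from compound 1 to compound 3 (0.09 log units; that floor lies within the scatter). Only a floor can be read from that comparison, as one end of it is a limit: the limit of > 200000 nM in this assay, at which 1 of the 3 values shown sits.

As far as these compounds go, whether a longer chain, a cyclohexyl ring or a chain ending in an amine on the sulfur would stay in this range remains open. A carboxylic acid there is equally untested by the compounds shown.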